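Chloro for Fluoro Repeated on a Second Core

The source may hold more compounds than are shown below. What is called first, only, known or untested is meant among the compounds shown, and "the series" means these compounds.

Compound 1 `CC(=O)OC1C(CF)OC(n2c(Cl)nc3cc(Cl)c(Cl)cc32)C1OC(C)=O` and compound 2 `CC(=O)OC1C(CCl)OC(n2c(Cl)nc3cc(Cl)c(Cl)cc32)C1OC(C)=O` share a core and differ by chloro in place of fluoro on a saturated chain carbon bound to a saturated ring carbon. In a functional assay on HFF cells (Homo sapiens) for cytotoxicity (a lower number here means a stronger inhibitor, a higher number a weaker inhibitor), compound 1 gives 32000 nM, and compound 2 gives 32000 nM; the step of no change at the digits printed from compound 1 to compound 2 (within the scatter). Compound 3 `O[C@@H]1[C@@H](CF)OC(n2c(Cl)nc3cc(Cl)c(Cl)cc32)[C@@H]1O` has a different core; the difference between the two cores is not broken down here. In this assay compound 3 gives 32000 nM, level with compounds 1 and 2. Compound 4 `O[C@@H]1[C@@H](CCl)OC(n2c(Cl)nc3cc(Cl)c(Cl)cc32)[C@@H]1O` differs from compound 3 by chloro in place of fluoro on a saturated chain carbon bound to a saturated ring carbon, the same change at the same place as before. That earlier step no change at the digits printed from compound 1 to compound 2 (within the scatter) was flat, and the same is expected now. Compound 4 is therefore estimated at 32000 nM in this assay, between 16000 nM and 64000 nM. The expected step is no change at the digits printed from compound 3 to compound 4 (within the scatter).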

Compound 4, half-maximal inhibitory concentration: 32000 nM
Compound 4: the middle estimate sits on the measured number at the digits printed; the measured number falls inside the stated range.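

In this assay the change of chloro for fluoro reads no change at the digits printed from compound 3 to compound 4 (within the scatter), and the step on the second core matches the one on the first: the same change on two cores in this assay, no change at the digits printed (within the scatter) from compound 1 to compound 2 and no change at the digits printed (within the scatter) from compound 3 to compound 4, 1.0-fold (0.00 log units) apart, within the scatter of two such steps This shows that on these two cores the change leaves the read-out where it stood. It does not show that the same would hold on a third core, and it gives no reason for the flat result, since all four compounds print one and the same value.

The compounds shown leave open what a bromo, hydroxy or amine group would do on a saturated chain carbon bound to a saturated ring carbon. They also leave open what a longer chain in place of fluoromethyl or chloromethyl would do.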